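Inverting one ring stereocentre on the aminocyclopentyl amide

The compounds below may be only part of what the source reports. "The series", "measured", "known", "first", "only" and "open" are said of these compounds alone.

In an assay for inhibition of MAP/microtubule affinity-regulating kinase 3 (Homo sapiens), read by HTRF, with a stated time of 2 h (a higher number here means a weaker inhibitor, a lower number a stronger inhibitor), compound 1 `Cn1cc(-c2cnc3c(-c4csc(C(=O)N[C@@H]5CCC[C@@H]5O)c4)cnn3c2)cn1` gives 43 nM, while compound 2 `Cn1cc(-c2cnc3c(-c4csc(C(=O)N[C@@H]5CCC[C@H]5N)c4)cnn3c2)cn1` gives 3 nM. Within the data shown here, compound 2 stands at the lowest number of the two measured, the single step to it being a 14-fold lower number from compound 1 to compound 2 (1.16 log units; beyond the scatter), the amino group in place of the hydroxyl on the ring carbon.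

Compound 3 `Cn1cc(-c2cnc3c(-c4csc(C(=O)N[C@@H]5CCC[C@@H]5N)c4)cnn3c2)cn1` keeps every atom and bond of compound 2 and differs only by the two compounds have the same atoms and bonds and differ only in configuration as drawn: 1 of 2 stereo elements differ; a stereocentre at a saturated ring carbon is drawn R in compound 2 and S in compound 3. Among the measured compounds shown here, no measured step turns a centre; the one step on record, a 14-fold lower number from compound 1 to compound 2 (1.16 log units; beyond the scatter), swaps one group for another and so says nothing about which drawing of the ring is favoured. A shift in this assay for compound 3 is expected, most likely toward a higher number, as a 4.0-fold higher number from compound 2 to compound 3 (0.60 log units; beyond the scatter), though the direction is not anchored by any measurement. Compound 3 is therefore estimated at 12 nM, within 2.5 nM to 60 nM.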

Compound 3, half-maximal inhibitory concentration: 2 nM
Estimate against measurement, compound 3: 6.0-fold (0.78 log units) above; measured number below the stated range.
By their numbers in this assay, from the lowest: compounds 3 and 2 (each within the scatter of the next); then compound 1.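

Turning this ring centre gives a 1.5-fold lower number from compound 2 to compound 3 (0.18 log units; within the scatter), so in this assay the two drawings of the amino-bearing ring cannot be told apart on these numbers. The comparison is a clean one: the fact that compounds 2 and 3 differ only in the configuration as drawn. Amino in place of hydroxy also gives a 22-fold lower number from compound 1 to compound 3 (1.33 log units; beyond the scatter), so the large step seen earlier for amino holds with either drawing of this centre, in the two amino compounds shown.

Still open, going by these compounds, is how the second ring stereocentre, drawn alike in compound 2 and compound 3, bears on the number in this assay, and whether the hydroxy compound would respond to turning a centre as the amino pair does. Also open, on these data alone, is whether a dimethylamino group or an aminomethyl group on the ring would keep numbers of this order.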